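The source may hold more compounds than are shown below. What is called first, only, known or untested is meant among the compounds shown, and "the series" means these compounds.

Measured in a functional assay on HUVEC cells (Homo sapiens), read by scintillation counting and thymidine incorporation, with a stated time of 24 h; on this read-out lower numbers stand for stronger inhibition and higher numbers for weaker inhibition:
compound 1 `CCC(C)n1ncn(-c2ccc(N3CCN(c4ccc(OC[C@@H]5CO[C@@](Cn6cnc(C(F)(F)F)n6)(c6ccc(Cl)cc6Cl)O5)cc4)CC3)cc2)c1=O`: 270 nM
compound 2 `CCC(C)n1ncn(-c2ccc(N3CCN(c4ccc(OC[C@@H]5CO[C@@](Cn6cc(C)nc6C)(c6ccc(Cl)cc6Cl)O5)cc4)CC3)cc2)c1=O`: 492 nM
compound 3 `CCC(C)n1ncn(-c2ccc(N3CCN(c4ccc(OC[C@@H]5CO[C@@](Cn6cnnn6)(c6ccc(Cl)cc6Cl)O5)cc4)CC3)cc2)c1=O`: 73 nM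

Compound 3 gives the lowest number of the three, and it stands clear of both others: the data show a 3.7-fold lower number from compound 1 to compound 3 (0.57 log units; beyond the scatter) and a 6.7-fold lower number from compound 2 to compound 3 (0.83 log units; beyond the scatter). Compounds 1 and 2 themselves do not separate, with a 1.8-fold higher number from compound 1 to compound 2 (0.26 log units; within the scatter).

The next compound, compound 4 `CCC(C)n1ncn(-c2ccc(N3CCN(c4ccc(OC[C@@H]5CO[C@@](Cn6nnnc6-c6ccccc6)(c6ccc(Cl)cc6Cl)O5)cc4)CC3)cc2)c1=O`, keeps everything in compound 3 except one change, phenyl in place of hydrogen on an aromatic carbon, so that 1H-tetrazol-1-yl becomes 5-phenyl-1H-tetrazol-1-yl.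

Among the compounds with values here, no measured step adds a group to this same ring, so the evidence is indirect. The two steps to compound 3 replace whole rings, but both start from a ring bearing substituents and end at the bare 1H-tetrazol-1-yl, and both lower the number. Read in reverse, they suggest that a substituent on this ring should raise the number by a modest amount of similar size, though the phenyl group itself is untested. An expected step of a 2.7-fold higher number from compound 3 to compound 4 (0.44 log units; beyond the scatter) is therefore estimated. For compound 4 the expected value is about 200 nM, with an estimated range from 60 nM to 650 nM.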

Compound 4, half-maximal inhibitory concentration: 119 nM
For compound 4 the middle estimate is 1.7-fold (0.23 log units) above the measured one, and the stated range covers the measured number.
By their numbers in this assay, from the lowest: compounds 3 and 4 (each within the scatter of the next); then compounds 1 and 2 (each within the scatter of the next).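

In this assay, phenyl in place of hydrogen on the aromatic carbon of the 1H-tetrazol-1-yl ring gives a 1.6-fold higher number from compound 3 to compound 4 (0.21 log units; within the scatter) and so does not separate the two compounds, which shows that this position can carry a group of 6 heavy atoms without a change beyond the scatter. The substituted ring also stays apart from the other two rings, with a 4.1-fold lower number from compound 2 to compound 4 (0.62 log units; beyond the scatter) and a 2.3-fold lower number from compound 1 to compound 4 (0.36 log units; beyond the scatter) in the same read-out, so among these four compounds both tetrazole rings, bare or phenyl-bearing, sit apart from the 2,4-dimethyl-1H-imidazol-1-yl and 3-(trifluoromethyl)-1H-1,2,4-triazol-1-yl rings, and no compound shown goes against this. Nothing given here accounts for this tolerance of the phenyl group or for the gap between the ring types.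

As far as these compounds go, whether the same carbon would accept a methyl, an amine, a carboxylic acid or a longer alkyl chain as readily as phenyl remains open. From the compounds shown here alone, it is also open whether a phenyl ring carrying its own substituent, such as a fluoro or methoxy group, would stay level with compound 3 or move away from it.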